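The compounds below may be only part of what the source reports. "The series", "measured", "known", "first", "only" and "open" are said of these compounds alone.

Compound 1 `Brc1ccccc1CSc1nnc(-c2ccncc2)n1-c1ccccc1` and compound 2 `COc1ccc(/C=N/NC(=O)CSc2nnc(-c3ccncc3)n2-c2ccccc2)cc1` share one core but carry very different side chains. In a functional assay on HCT-116 cells (Homo sapiens) for inhibition, read by MTT assay, with a stated time of 48 h (on this read-out lower numbers stand for stronger inhibition and higher numbers for weaker inhibition), compound 1 gives 20200 nM and compound 2 gives 19200 nM. These two numbers lie within the usual scatter of repeated measurements, so compound 2 stands level with compound 1 and neither can be ranked above the other.

Compound 3 `O=C(CSc1nnc(-c2ccncc2)n1-c1ccccc1)N/N=C/c1cc(Br)ccc1O` keeps the frame of compound 2 and changes one group: 5-bromo-2-hydroxyphenyl in place of 4-methoxyphenyl on a carbon with a double bond to nitrogen. Put simply, 5-bromo-2-hydroxyphenyl sits in place of 4-methoxyphenyl on a carbon with a double bond to nitrogen.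

For the measured compounds named here, no measured pair here differs in one place alone, so nothing measured speaks directly to this swap. Going by the values given here, the only guide is that the quite different side chain of compound 1 still leaves it level with compound 2 at 19200 nM, which argues against expecting a large change. In this assay, a modest move toward a lower number is expected, an estimated 1.6-fold lower number from compound 2 to compound 3 (0.20 log units; within the scatter). For compound 3 the estimated value is 12000 nM, with an expected range from 4000 nM to 35000 nM.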

Compound 3, half-maximal inhibitory concentration: 1990 nM
For compound 3 the middle estimate is 6.0-fold (0.78 log units) above the measured one; the measured number lies below the stated range.
By their numbers in this assay, from the lowest: compound 3; then compounds 2 and 1 (each within the scatter of the next).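

The group on the carbon with a double bond to nitrogen clearly matters in this assay: putting 5-bromo-2-hydroxyphenyl in place of 4-methoxyphenyl gives a 9.6-fold lower number from compound 2 to compound 3 (0.98 log units; beyond the scatter). Heavy-atom count does not separate the two groups, since each has the same number and each holds one six-membered aromatic ring of carbon only. The entering group instead differs in its atoms and donor count, bringing a bromine and one hydrogen-bond donor, and no measurement shown here explains why the number falls with this change.

Because the bromine and the hydroxyl enter together while the methoxy leaves, the compounds shown cannot tell which of these changes accounts for the step. A ring carrying only the hydroxyl or only the bromine would begin to separate them, while a chlorine in place of the bromine or an amine in place of the hydroxyl would test how specific each atom's role is at this position.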